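The compounds below may be only part of what the source reports. "The series", "measured", "known", "first", "only" and "open" are said of these compounds alone.

Three compounds built on a shared core were measured in a functional assay on HeLa cells (Homo sapiens) for antiproliferative activity, read by sulforhodamine B assay, with a stated time of 48 h; on this read-out higher numbers stand for weaker inhibition and lower numbers for stronger inhibition. Compound 1 `COc1cc(OC)c2sc(-c3ccc(N/C=C\C(=O)c4cc(OC)c(OC)c(OC)c4)c(C)c3)nc2c1` gives 16400 nM in this assay. Compound 2 `COc1cc(C(=O)/C=C\Nc2ccc(-c3nc4cc(OC)c(OC)c(OC)c4s3)cc2)cc([N+](=O)[O-])c1OC` gives 7800 nM in this assay, the lowest number of the three. Compound 3 `COc1cc(C(=O)/C=C\Nc2ccc(-c3nc4cc(OC)c(OC)c(OC)c4s3)cc2C)cc(OC)c1OC` gives 11100 nM in this assay. The difference between the cores of compound 2 and compound 3 is not broken down here. From compound 3 to compound 1 the change is hydrogen in place of methoxy on an aromatic carbon, and it made a 1.5-fold higher number from compound 3 to compound 1 (0.17 log units; within the scatter).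

Compound 4 `COc1cc(OC)c2sc(-c3ccc(N/C=C\C(=O)c4cc(OC)c(OC)c([N+](=O)[O-])c4)cc3)nc2c1` has not yet been measured in this assay. It is reached from compound 2 by hydrogen in place of methoxy on an aromatic carbon, the same change as from compound 3 to compound 1, at a place described in the same words. Because a 1.5-fold higher number from compound 3 to compound 1 (0.17 log units; within the scatter) lay within the scatter, compound 4 is expected to stand close to compound 2, with a step estimated at a 1.5-fold higher number from compound 2 to compound 4 (0.17 log units; within the scatter). Compound 4 is therefore estimated at 11500 nM in this assay, with a range from 5500 nM to 25000 nM expected.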

Compound 4, half-maximal inhibitory concentration: 19000 nM
Compound 4: the middle estimate sits 1.7-fold (0.22 log units) below what was measured; measured number inside the range.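

In this assay, hydrogen in place of methoxy on an aromatic carbon gave a 2.4-fold higher number from compound 2 to compound 4 (0.39 log units; beyond the scatter). Set beside the same change on the other core, with a 1.5-fold higher number from compound 3 to compound 1 (0.17 log units; within the scatter), the two steps cannot be told apart: the same change on two cores in this assay, a 1.5-fold higher number (0.17 log units; within the scatter) from compound 3 to compound 1 and a 2.4-fold higher number (0.39 log units; beyond the scatter) from compound 2 to compound 4, 1.6-fold (0.22 log units) apart, within the scatter of two such steps This shows that the change carried from one core to the other in these two pairs with no difference in size beyond the scatter, although only the step to compound 4 lies beyond the scatter on its own, and it does not show that the step would hold on any further core of the series.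

At this aromatic carbon the compounds shown hold only methoxy or hydrogen, so how a chlorine atom, an ethoxy group or a carboxylic acid would read there remains open. Also open, as far as these compounds go, is whether the step would stay the same on a core carrying neither the methyl group of compound 3 nor the nitro group of compound 2.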